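A few compounds are considered here, and "the series" means these few. Any claim that something is new, unique, unknown or untested is made for them only; others in the source may bear on it.

This study follows a small set of compounds built on one shared core, each carrying a different group on the same aromatic carbon of that core. Their fate was followed in an ADME assay on microsomes from liver (Homo sapiens) for metabolic stability, read by LC-MS, using NADPH, with stated times of 10 min and 45 min, tested at 1 uM; on this read-out higher numbers stand for fast clearance and lower numbers for slow clearance. Compound 1 `COC(c1cc(Cl)c2c(c1Cl)C(=O)N(Cc1c(C)cc(C)[nH]c1=O)CC2)C1CCOC1` gives 136 uL/min; 93.3 uL/min; 128 uL/min; 108 uL/min (4 entries) in this assay, and compound 2 `COC(c1cc(Cl)c2c(c1Cl)C(=O)N(Cc1c(C)cc(C)[nH]c1=O)CC2)C1CCOCC1` gives 130 uL/min; 129 uL/min (2 entries), so both are cleared quickly. Going by the values given here, compound 3 `Cc1cc(C)c(CN2CCc3c(Cl)cc([C@@H](C)CO)c(Cl)c3C2=O)c(=O)[nH]1` sits far lower: in this assay compound 3 gives 12.4 uL/min, the only single number it has, alongside two further entries that did not yield a single number. Compound 4 `Cc1cc(C)c(CN2CCc3c(Cl)cc(-c4c(C)noc4C)c(Cl)c3C2=O)c(=O)[nH]1` has not yet been measured. It differs from compound 3 in one place: 3,5-dimethyl-1,2-oxazol-4-yl in place of 1-(hydroxymethyl)ethyl on an aromatic carbon. Among the compounds with values here, no measured pair in this set changes only at that position, so the size of the step cannot be read from a neighbour. Because compound 1 gives 136 uL/min; 93.3 uL/min; 128 uL/min; 108 uL/min (4 entries) and compound 2 gives 130 uL/min; 129 uL/min (2 entries) while compound 3 gives 12.4 uL/min, the hydroxymethyl-bearing compound is the one outlier toward slow clearance, and the step is expected to be a rise beyond the scatter, a 3.2-fold higher number from compound 3 to compound 4 (0.51 log units; beyond the scatter). Compound 4 is therefore estimated at 40 uL/min, with a range from 12 uL/min to 120 uL/min.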

Compound 4, intrinsic clearance in a liver preparation (reported as CLH), per the amount of preparation that the assay uses in the liver assay: 107 uL/min
The estimate for compound 4 lay 2.7-fold (0.43 log units) below the measured number, and the stated range covers the measured number.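

Going by these compounds alone, in the liver assay, the first direct reading at this aromatic carbon is an 8.6-fold higher number from compound 3 to compound 4 (0.94 log units; beyond the scatter), on replacing 1-(hydroxymethyl)ethyl with 3,5-dimethyl-1,2-oxazol-4-yl. The shared core alone therefore does not keep the number low, since compound 4 returns to the region occupied by a compound with another group at this same carbon, compound 1: the several entries of compound 1 in the liver assay, 136 uL/min; 93.3 uL/min; 128 uL/min; 108 uL/min (4 entries) In a physicochemical assay for lipophilicity, at pH 7.4 (a lower number here means a more polar compound, a higher number a more lipophilic compound), compound 3 gives 2.5 and compound 4 gives 3.1, a gap beyond the usual scatter, so both read-outs move upward together in this single pair.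

This one pair cannot separate the effects of losing the hydroxyl group, gaining the five-membered aromatic ring and shifting the number in the physicochemical assay, as all three changes arrive together. A longer chain ending in a hydroxyl group, a carboxylic acid or an amine at this aromatic carbon would be needed to show whether the low number of compound 3 depends on that hydroxyl group or on the absence of an aromatic ring here.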